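The source may report more compounds than this note shows. Statements on the series, on what has been measured and on what is new or still open speak of the compounds shown alone.

Three compounds share one core and differ only in the group carried on the aromatic ring. In a functional assay on OVCAR-3 cells (Homo sapiens) for cytotoxicity, read by sulforhodamine B assay (a lower number here means a stronger inhibitor of growth, a higher number a weaker inhibitor of growth), compound 1 `COc1ccc(/C=N\NC(=S)NC(C)(C)CCC[C@](C)(O)[C@@H]2CC=C(C)CC2)cc1` gives 15800 nM, compound 2 `CC1=CC[C@@H]([C@@](C)(O)CCCC(C)(C)NC(=S)N/N=C\c2ccccc2[N+](=O)[O-])CC1` gives 16200 nM, and compound 3 `CC1=CC[C@@H]([C@@](C)(O)CCCC(C)(C)NC(=S)N/N=C\c2ccc([N+](=O)[O-])cc2)CC1` gives 88600 nM, the highest of the three numbers. The step of a 5.6-fold higher number from compound 1 to compound 3 (0.75 log units; beyond the scatter) and the step of a 5.5-fold higher number from compound 2 to compound 3 (0.74 log units; beyond the scatter) both place compound 3 beyond the scatter above its neighbours. Compound 4 `CC1=CC[C@@H]([C@@](C)(O)CCCC(C)(C)NC(=S)N/N=C\c2ccc(Cl)cc2)CC1` differs from compound 3 in one place: chloro in place of nitro on an aromatic carbon. For the measured compounds named here, no measured step exchanges nitro for chloro, so the two modest rises into compound 3 are the only bearing. The step from compound 3 to compound 4 is expected to run the other way, as a 3.0-fold lower number from compound 3 to compound 4 (0.47 log units; beyond the scatter). Compound 4 is therefore estimated at 30000 nM, within a range from 10000 nM to 90000 nM.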

Compound 4, concentration for total growth inhibition: 12800 nM
Compound 4: middle estimate off by 2.3-fold (0.37 log units), on the high side; the measured number falls inside the stated range.
By their numbers in this assay, from the lowest: compounds 4, 1 and 2 (each within the scatter of the next); then compound 3.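

In this assay the step of a 6.9-fold lower number from compound 3 to compound 4 (0.84 log units; beyond the scatter) shows that this place on the aromatic ring does not simply lose activity when a nitro group is replaced: with chloro, the number returns to the level of the other compounds. The steps of a 1.3-fold lower number from compound 2 to compound 4 (0.10 log units; within the scatter) and a 1.2-fold lower number from compound 1 to compound 4 (0.09 log units; within the scatter) lie within the scatter, so 4-chlorophenyl cannot be told apart from either 2-nitrophenyl or 4-methoxyphenyl, leaving compound 3 alone apart. No measurement shown explains this difference. From the compounds shown here alone, whether an amine or a carboxylic acid at this place would match compound 4 or compound 3 remains open.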